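From isopropyl to butyl on the amide

This account rests on a few compounds, and the source may have more. Where it says the series, first, only, none or still open, it means among the compounds named here.

Compound 1 `CCCCc1oc2ccccc2c1C(=O)c1ccc(OCC(N)=O)cc1` gives > 50000 nM as a limit
Compound 2 `CCCCc1oc2ccccc2c1C(=O)c1ccc(OCC(=O)NC(C)C)cc1` gives > 50000 nM as a limit

In a functional assay on MCF7 cells (Homo sapiens) for antiproliferative activity, read by MTT assay, with a stated time of 24 h (a lower number here means a stronger inhibitor, a higher number a weaker inhibitor), compound 2 reads > 50000 nM as a limit of the assay and not a number. Its position is therefore the limit of > 50000 nM in this assay, at which 2 of the 2 values shown sit, and no more. Compound 3 `CCCCNC(=O)COc1ccc(C(=O)c2c(CCCC)oc3ccccc23)cc1` carries butyl in place of isopropyl on an amide-type nitrogen. For the measured compounds named here, the only measured step bearing on this is a step that the two limits leave unreadable from compound 1 to compound 2 and it offers no size to carry forward. The data therefore give no reason to expect a change beyond the scatter in this assay, in either direction, and compound 3 may well report only a limit too. The estimated change is a number no higher from compound 2 to compound 3 (the limit leaves the size open) in size. The expected value for compound 3 is 50000 nM (estimated range 20000 nM to 100000 nM).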

Compound 3, half-maximal inhibitory concentration: > 50000 nM
Compound 3 gave a limit, no number; the forecaster's own chance of this, stated with the estimate: 70%; the middle value sits exactly at the limit.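

Compound 1, compound 2 and compound 3 each give only a limit of the assay and not a number, so no step among them can be read: the limit of > 50000 nM in this assay, at which 3 of the 3 values shown sit.

The compounds shown leave open whether the amide hydrogen, isopropyl or butyl makes any difference in this assay.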